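Moving the Methoxy Group Around the Phenyl Ring

The compounds below may be only part of what the source reports. "The series", "measured", "known", "first", "only" and "open" are said of these compounds alone.

Compound 1 `O=[N+]([O-])c1ccc(CN2CCC(n3cc(CC(OCc4cc(-c5ccccc5)no4)c4ccc(Br)cc4)nn3)CC2)cc1` gives a value in a functional assay on MCF7 cells (Homo sapiens) for cytotoxicity, with a stated time of 48 h (a higher number here means a weaker inhibitor, a lower number a stronger inhibitor), of > 25000 nM, which is a limit of the assay rather than a number. Compound 2 `N#Cc1ccc(-c2cc(COC(Cc3cn(C4CCN(Cc5ccc([N+](=O)[O-])cc5)CC4)nn3)c3ccc(Br)cc3)on2)cc1` gives 3000 nM in this assay. Compound 3 `COc1cccc(-c2cc(COC(Cc3cn(C4CCN(Cc5ccc([N+](=O)[O-])cc5)CC4)nn3)c3ccc(Br)cc3)on2)c1` gives 7000 nM in this assay.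

Among the two numbers that are known, compound 3 stands at the higher end, with compound 2 nearest to it: a 2.3-fold higher number from compound 2 to compound 3 (0.37 log units; beyond the scatter). The two measured steps that start from compound 1 rest on its limit (the limit of > 25000 nM in this assay, at which 1 of the 3 values shown sits), so only a lower bound on their size can be given: an at least 8.3-fold lower number from compound 1 to compound 2 (0.92 log units; beyond the scatter) and an at least 3.5-fold lower number from compound 1 to compound 3 (0.55 log units; beyond the scatter).

Compound 4 `COc1ccccc1-c1cc(COC(Cc2cn(C3CCN(Cc4ccc([N+](=O)[O-])cc4)CC3)nn2)c2ccc(Br)cc2)on1` differs from compound 3 in one place: 2-methoxyphenyl in place of 3-methoxyphenyl on an aromatic carbon. Among the compounds with values here, none of the measured steps moves the methoxy group from one position on the phenyl ring to another; the step between compound 2 and compound 3 exchanges a cyanophenyl for a methoxyphenyl and so does not speak directly to this change. With no closer comparison at hand, the expected step from compound 3 to compound 4 in this assay is no change at the digits printed from compound 3 to compound 4 (within the scatter), that is, none beyond the usual scatter. Compound 4 is therefore estimated to give 7000 nM in this assay, in the range 2500 nM to 20000 nM.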

Compound 4, half-maximal inhibitory concentration: 3000 nM
Estimate against measurement, compound 4: 2.3-fold (0.37 log units) above; the measured number falls inside the stated range.
By their numbers in this assay, from the lowest: compounds 2 and 4 (each within the scatter of the next); then compound 3. At a limit, above all of these: compound 1.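

Within the data shown here, this is the first pair in which the same methoxy group changes place on the phenyl ring while all else stays fixed, and a 2.3-fold lower number from compound 3 to compound 4 (0.37 log units; beyond the scatter) shows that in this assay its placement on this ring alone can shift the result beyond the scatter. The second comparison, no change at the digits printed from compound 2 to compound 4 (within the scatter), shows that 2-methoxyphenyl and 4-cyanophenyl, two different groups at different places on the ring, cannot be told apart in this assay, so the kind of group does not settle the outcome on its own among these compounds. Compound 1, which has a plain phenyl ring, carries a limit of the assay rather than a number, so the gain on adding the methoxy group in this position has only a lower bound, an at least 8.3-fold lower number from compound 1 to compound 4 (0.92 log units; beyond the scatter): the limit of > 25000 nM in this assay, at which 1 of the 4 values shown sits.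

The series still lacks 4-methoxyphenyl, so the methoxy walk around the ring is incomplete, and these numbers give no reason for the difference between the two placements. As far as these compounds go, whether that difference holds for other groups, such as 2-aminophenyl against 3-aminophenyl or 2-cyanophenyl against 3-cyanophenyl, also remains open.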